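The source may hold more compounds than are shown below. What is called first, only, known or untested is meant among the compounds shown, and "the series" means these compounds.

Measured so far:
compound 1 `C=C1[C@@H](O[Si](C)(C)C(C)(C)C)C[C@H]2C(C)(C)CCC[C@]2(C)[C@H]1C[C@H](O)c1ccoc1`: 7.71 ug/mL
compound 2 `C=C1[C@@H](O[Si](C)(C)C(C)(C)C)C[C@H]2C(C)(C)CCC[C@]2(C)[C@H]1C[C@@H](O)c1ccoc1`: 3.76 ug/mL
compound 3 `C=C1[C@@H](O)C[C@H]2C(C)(C)CCC[C@]2(C)[C@H]1C[C@H](O)c1ccoc1`: 29.7 ug/mL

In a functional assay on HUVEC cells (Homo sapiens) for inhibition, read by colorimetric assay and MTT assay (a lower number here means a stronger inhibitor, a higher number a weaker inhibitor), compound 3 stands highest of the three numbers; its nearest neighbour is reached by a 3.9-fold higher number from compound 1 to compound 3 (0.59 log units; beyond the scatter), and compound 2 lies further off. Compound 4 `C=C1[C@@H](O)C[C@H]2C(C)(C)CCC[C@]2(C)[C@H]1C[C@@H](O)c1ccoc1` keeps every atom of compound 3: the two compounds have the same atoms and bonds and differ only in configuration as drawn: 1 of 5 stereo elements differ; a stereocentre at a saturated chain carbon is drawn S in compound 3 and R in compound 4. Among the measured compounds shown here, the one measured step that bears on this change is a 2.1-fold lower number from compound 1 to compound 2 (0.31 log units; beyond the scatter), the same inversion at the same stereocentre on the pair carrying the group of 7 heavy atoms, a pair that is otherwise identical (the fact that compounds 1 and 2 differ only in the configuration as drawn). A step of similar size and direction is therefore expected here, a 2.1-fold lower number from compound 3 to compound 4 (0.33 log units; beyond the scatter), modest but beyond the scatter. Compound 4 is estimated at 14 ug/mL in this assay, with a range of 7 ug/mL to 30 ug/mL.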

Compound 4, half-maximal inhibitory concentration: 15 ug/mL
Estimate against measurement, compound 4: 1.1-fold (0.03 log units) below; the measured number falls inside the stated range.
By their numbers in this assay, from the lowest: compound 2; then compounds 1, 4 and 3 (each within the scatter of the next, the first and the last beyond it).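

In this assay, the inversion at the saturated chain carbon, with hydrogen on the oxygen, gives a 2.0-fold lower number from compound 3 to compound 4 (0.30 log units; within the scatter), so on this pair the configuration is not separated from the scatter. Placing hydrogen on the oxygen instead of the group of 7 heavy atoms now also reads on the second configuration, as a 4.0-fold higher number from compound 2 to compound 4 (0.60 log units; beyond the scatter), and the step holds its size on both configurations: the same change on two cores in this assay, a 3.9-fold higher number (0.59 log units; beyond the scatter) from compound 1 to compound 3 and a 4.0-fold higher number (0.60 log units; beyond the scatter) from compound 2 to compound 4, 1.0-fold (0.02 log units) apart, within the scatter of two such steps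

Open, on these data alone, is where a smaller group on that oxygen, such as a methyl ether or an acetyl ester, would fall between these values.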